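The source may report more compounds than this note shows. Statements on the series, on what has been measured and on what is new or still open speak of the compounds shown alone.

Measured so far in an assay on isolated protein for inhibition of protein kinase C epsilon type (Homo sapiens), read by coupled enzyme assay; a lower number here means a stronger inhibitor, a higher number a weaker inhibitor:
compound 1 `N#CC1(c2cc(CCO)cc(-c3ccnc4[nH]nc(C(F)(F)F)c34)c2)CC1` — 25 nM
compound 2 `CC(C)C(O)Cc1cc(-c2ccnc3[nH]nc(C(F)(F)F)c23)cc(C2(C#N)CC2)c1` — 215 nM
compound 3 `N#CC1(c2cc(CC(O)C3CC3)cc(-c3ccnc4[nH]nc(C(F)(F)F)c34)c2)CC1` — 30 nM

Compound 3 stands second highest of the three numbers. Its nearest neighbour is compound 1, and a 1.2-fold higher number from compound 1 to compound 3 (0.08 log units; within the scatter) lies within the scatter, whereas a 7.2-fold lower number from compound 2 to compound 3 (0.86 log units; beyond the scatter) lies beyond it. The three compounds differ only in the group on a saturated chain carbon bound to an oxygen on a saturated carbon and a saturated chain carbon: hydrogen in compound 1, isopropyl in compound 2, cyclopropyl in compound 3.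

Compound 4 `N#CC1(c2cc(CC(O)C(F)(F)F)cc(-c3ccnc4[nH]nc(C(F)(F)F)c34)c2)CC1` continues that variation: trifluoromethyl in place of cyclopropyl on a saturated chain carbon bound to an oxygen on a saturated carbon and a saturated chain carbon. Among the measured compounds shown here, no measured step repeats this change. For the measured compounds named here, the steps that bear on it show hydrogen and cyclopropyl giving numbers within the scatter of each other (a 1.2-fold higher number from compound 1 to compound 3 (0.08 log units; within the scatter)), while isopropyl gives a higher number (an 8.6-fold higher number from compound 1 to compound 2 (0.93 log units; beyond the scatter)). Whether trifluoromethyl, which has no ring, behaves like cyclopropyl or like isopropyl cannot be read from these three compounds, so the range must be wide. The step of a 2.0-fold higher number from compound 3 to compound 4 (0.30 log units; within the scatter) is expected to run toward a higher number but to stay short of the size of an 8.6-fold higher number from compound 1 to compound 2 (0.93 log units; beyond the scatter). Compound 4 is estimated in this assay at 60 nM, between 20 nM and 200 nM.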

Compound 4, inhibition constant: 267 nM
For compound 4 the middle estimate is 4.5-fold (0.65 log units) below the measured one; measured number outside the range, above it.
By their numbers in this assay, from the lowest: compounds 1 and 3 (each within the scatter of the next); then compounds 2 and 4 (each within the scatter of the next).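

In this assay, trifluoromethyl does not stay level with cyclopropyl on this saturated chain carbon bound to an oxygen (an 8.9-fold higher number from compound 3 to compound 4 (0.95 log units; beyond the scatter)), so the parity between hydrogen and cyclopropyl does not extend to every group placed here. Trifluoromethyl instead falls level with isopropyl (a 1.2-fold higher number from compound 2 to compound 4 (0.09 log units; within the scatter)) and well away from hydrogen (an 11-fold higher number from compound 1 to compound 4 (1.03 log units; beyond the scatter)), which splits the four compounds into two clear tiers: compounds 1 and 3 in one, compounds 2 and 4 in the other. Both groups in the higher tier lack a ring and cyclopropyl has one, but hydrogen also lacks a ring and goes against any simple reading by ring alone, and no measurement on these compounds accounts for the split.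

On these data alone, it remains open whether a methyl, an ethyl or a cyclobutyl on the same carbon would join compounds 1 and 3 or compounds 2 and 4. It is also open whether the two tiers would persist if an amine took the place of the hydroxyl, since every compound shown carries the oxygen.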